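This account rests on a few compounds, and the source may have more. Where it says the series, first, only, none or still open, it means among the compounds named here.

Going by the values given here, compound 1, with structure `COc1cccc(CCCC(=O)Nc2nc3ccccc3c(=O)s2)c1`, is the only member of this small set with a number to its name: in an assay on CHO cells for displacement of a labelled ligand from adenosine receptor A1 (Homo sapiens), read by scintillation counting, with a stated time of 90 min (a higher number here means a weaker inhibitor, a lower number a stronger inhibitor), compound 1 gives 214 nM. Two companions have no result recorded in this assay: compound 2, with structure `O=C(COc1cccc(Cl)c1)Nc1nc2ccccc2c(=O)s1`, stands at "not determined" (no result reported), and compound 3, with structure `Cc1sc2nc(NC(=O)CCCc3ccccc3)sc(=O)c2c1C`, stands at "not determined" (no result reported), so compound 1 stands alone. Compound 4, with structure `O=C(CCCc1cccc(Cl)c1)Nc1nc2ccccc2c(=O)s1`, has not been measured yet. It differs from compound 1 in one place: chloro in place of methoxy on an aromatic carbon. Among the compounds with values here, with no measured pair to compare, the expected step is small, an estimated 1.2-fold lower number from compound 1 to compound 4 (0.08 log units; within the scatter) that stays inside the usual scatter. Compound 4 is therefore expected to give about 180 nM in this assay, likely between 60 nM and 550 nM.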

Compound 4, inhibition constant: > 10000 nM
Compound 4 ended at the assay's limit; the forecaster's own chance of this, stated with the estimate: 5%; middle value at least 55-fold (1.74 log units) from the limit.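

In this assay, chloro in place of methoxy on this aromatic carbon gives an at least 46-fold higher number from compound 1 to compound 4 (1.66 log units; beyond the scatter), so a change of a single small group at this position can matter greatly, which compound 1 alone could not show. Compound 4 sits at a limit of the assay, not at a number: the limit of > 10000 nM in this assay, at which 1 of the 4 values shown sits.

The compounds shown leave open whether the loss of methoxy or the arrival of chloro drives this step. A hydrogen, a hydroxyl or a methyl at the same position would help to separate the two.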